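The compounds below may be only part of what the source reports. "The series", "measured", "known", "first", "only" and "open" are said of these compounds alone.

Three measured compounds share one core and differ only in the chain that joins the two aromatic parts. Compound 1 `CCCc1c(OCCCCOc2ccc(-c3nn[nH]n3)cc2)ccc(C(C)=O)c1O` is the strongest of the three in an assay on isolated protein for binding affinity to metabotropic glutamate receptor 2 (Homo sapiens), read by GTPgammaS binding (on this read-out higher numbers stand for an effect only at larger amounts of compound and lower numbers for an effect already at smaller amounts), where compound 1 gives 348 nM. Compound 2 `CCCc1c(OCCCOc2ccc(-c3nn[nH]n3)cc2)ccc(C(C)=O)c1O`, with a shorter chain, gives 1420 nM in this assay. Compound 3 `CCCc1c(OCCCCCOc2ccc(-c3nn[nH]n3)cc2)ccc(C(C)=O)c1O`, with a longer chain, gives 3310 nM in this assay. Both of these numbers lie beyond the usual scatter from that of compound 1, so the chain of compound 1 is clearly the best of the three tried. Compound 4 `CCCc1c(OC(C)CCCOc2ccc(-c3nn[nH]n3)cc2)ccc(C(C)=O)c1O` keeps that chain and adds one change: methyl in place of hydrogen on a saturated chain carbon bound to an oxygen on an aromatic ring and a saturated chain carbon. For the measured compounds named here, no measured pair shows what such a branch does, so the expectation rests only on how sensitive the series is to chain shape between compounds 1, 2 and 3. For compound 4 a small weakening, not certainly beyond the scatter, is expected, a 1.9-fold higher number from compound 1 to compound 4 (0.27 log units; within the scatter). The estimate for compound 4 is 650 nM, with a range from 200 nM to 2500 nM.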

Compound 4, half-maximal effective concentration: 918 nM
For compound 4 the middle estimate is 1.4-fold (0.15 log units) below the measured one; the measured number falls inside the stated range.
By their numbers in this assay, from the lowest: compound 1; then compounds 4 and 2 (each within the scatter of the next); then compound 3.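

In this assay, methyl in place of hydrogen on a saturated chain carbon bound to an oxygen on an aromatic ring and a saturated chain carbon gives a 2.6-fold higher number from compound 1 to compound 4 (0.42 log units; beyond the scatter) and so counts as a modest weakening. For the compounds shown here, this is the first direct reading of a branch on the chain: compounds 1, 2 and 3 differ only in chain length, whereas compound 4 shows that this carbon does not take one added methyl without some loss, even when the chain length of compound 1 is kept. Nothing available here accounts for this loss.

From the compounds shown here alone, the effect of a larger group on this carbon, such as ethyl, or of a hydroxyl group there remains open. So does whether a methyl on another carbon of the chain would give a similar step.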